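A few compounds are considered here, and "the series" means these few. Any claim that something is new, unique, unknown or untested is made for them only; others in the source may bear on it.

In a functional assay on Caco-2 cells (Homo sapiens) for cytotoxicity, read by MTT assay, with stated times of 6 h and 48 h (a lower number here means a stronger inhibitor, a higher number a weaker inhibitor), compound 1 `Cn1c(-c2cc(-c3ccccc3)no2)cc(Br)c1Br` gives 16600 nM. Compound 2 `Cn1c(-c2cc(-c3ccc[nH]3)no2)cc(Br)c1Br` gives >= 100000 nM, and this is a limit of the assay rather than a number. On these data alone, compound 2 therefore sits at the weak end of this short series, and its true position is unknown. Going by the values given here, the only measured step is an at least 6.0-fold higher number from compound 1 to compound 2 (0.77 log units; beyond the scatter). Compound 3 `Brc1cc(-c2cc(-c3ccc[nH]3)no2)[nH]c1Br` differs from compound 2 in a single change: hydrogen in place of methyl on an aromatic nitrogen. This is hydrogen in place of methyl on an aromatic nitrogen. Among the compounds with values here, the measured step was made elsewhere in the molecule, so it bears on this change only loosely, and no measured pair shows what removing this methyl does. A modest move towards a lower number in this assay is expected, though it may not exceed the scatter. The expected step is an at least 1.4-fold lower number from compound 2 to compound 3 (0.15 log units; that floor lies within the scatter). Compound 3 is estimated at about 70000 nM, with an expected range of 20000 nM to 100000 nM.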

Compound 3, half-maximal inhibitory concentration: >= 100000 nM
Compound 3 was reported as a limit (the forecaster's own chance of this, stated with the estimate: 50%); middle value at least 1.4-fold (0.15 log units) away from the limit.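

In this assay compound 3 gives >= 100000 nM, which is a limit of the assay and not a number. Going by these compounds alone, compound 2 is also reported as a limit, so no step between compound 2 and compound 3 can be read: the limit of >= 100000 nM in this assay, at which 2 of the 3 values shown sit. The compounds shown leave open whether hydrogen in place of methyl on the aromatic nitrogen changes the number in this assay at all.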